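A longer side chain on compound 2

This account rests on a few compounds, and the source may have more. Where it says the series, first, only, none or still open, it means among the compounds named here.

- Compound 1 `CCN1CCN(CCCN(C[C@H]2Cc3ccccc3CN2)[C@H]2CCCc3cccnc32)CC1` gives 59%
- Compound 2 `c1ccc2c(c1)CN[C@@H](CN(CCN1CCNCC1)[C@H]1CCCc3cccnc31)C2` gives 96%
- Compound 3 `CN1CCN(CCCN(C[C@H]2Cc3ccccc3CN2)[C@H]2CCCc3cccnc32)CC1` is not yet measured

In an ADME assay on microsomes from liver (Homo sapiens) for metabolic stability, read by LC-MS, with a stated time of 10 min, tested at 0.5 uM (a higher number here means that more of the compound is left, a lower number that less of the compound is left), compound 2 at 96% stands highest of the two measured compounds. The change from compound 2 to compound 3 is (4-methylpiperazin-1-yl)methyl in place of piperazin-1-yl on a saturated chain carbon, two bonds along the chain from an amine nitrogen and nothing else. Among the measured compounds shown here, the one measured step bearing on it is a number 37 percentage points higher from compound 1 to compound 2 (beyond the scatter) and it ran nearly the opposite way, with piperazin-1-yl replacing (4-ethylpiperazin-1-yl)methyl at that place. One step is thin evidence, yet a large fall in this assay is expected. The estimate for this change is a number 30 percentage points lower from compound 2 to compound 3 (beyond the scatter) as the likely outcome. Compound 3 is expected at 66% (range 48% to 84%) once measured.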

Compound 3, percent of the compound remaining: 72%
For compound 3 the middle estimate is 6 percentage points below the measured one; measured number inside the range.
By their numbers in this assay, from the lowest: compound 1; then compound 3; then compound 2.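

In this assay, (4-methylpiperazin-1-yl)methyl in place of piperazin-1-yl gives a number 24 percentage points lower from compound 2 to compound 3 (beyond the scatter) and so separates part of the earlier large step, in which the chain and the end group changed together. Trimming the 4-ethyl group to 4-methyl on the same longer chain gives a number 13 percentage points higher from compound 1 to compound 3 (beyond the scatter) and shows that the group at the chain end also counts. Nothing measured here gives a reason for either step.

Still open, as far as these compounds go, is how much of the fall from compound 2 to compound 3 belongs to the longer chain and how much to the methyl, since the two change together. A morpholine at the end of the longer chain would test whether the piperazine ring itself matters.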